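Furan ring gives way to a hydroxyalkyl chain

The source may report more compounds than this note shows. Statements on the series, on what has been measured and on what is new or still open speak of the compounds shown alone.

Three amides built on one shared core have been examined in a physicochemical assay for lipophilicity; a higher number here means a more lipophilic compound, a lower number a more polar compound. Compound 1 `NS(=O)(=O)Oc1ccc2c(c1)CN(C(=O)c1ccc(N(Cc3ccccc3)Cc3ccco3)cc1)CC2` gives 1.93 there. Compound 2 `NS(=O)(=O)Oc1ccc2c(c1)CN(C(=O)c1ccc(N3CCN(Cc4ccccc4)CC3)cc1)CC2` gives 1.93 and compound 3 `CCN(Cc1ccc(F)cc1)c1ccc(C(=O)N2CCc3ccc(OS(N)(=O)=O)cc3C2)cc1` gives 1.93, so compound 1 stands level with both at the digits shown, within the scatter, and no order among the three can be drawn. Compound 4 `NS(=O)(=O)Oc1ccc2c(c1)CN(C(=O)c1ccc(N(CCCO)Cc3ccccc3)cc1)CC2` awaits measurement in this assay. It differs from compound 1 in one place: 2-hydroxyethyl in place of furan-2-yl on a saturated chain carbon bound to a nitrogen on an aromatic ring. Going by the values given here, no measured pair carries this change, so the size of its step has to be estimated. A downward step beyond the scatter is expected, estimated as a number 0.63 log units lower from compound 1 to compound 4 (beyond the scatter). Compound 4 is therefore expected at 1.3, within a range from 0.8 to 1.8.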

Compound 4, partition coefficient: 1.93
Estimate against measurement, compound 4: 0.63 log units below, and the stated range ends below it.
By their numbers in this assay, from the lowest: compounds 1, 2, 3 and 4 (each within the scatter of the next).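

In this assay there is no change at the digits printed from compound 1 to compound 4 (within the scatter) when 2-hydroxyethyl takes the place of furan-2-yl on a saturated chain carbon bound to a nitrogen on an aromatic ring. Going by these compounds alone, at this place, then, losing the five-membered aromatic ring and gaining a hydrogen-bond donor leaves the read-out unmoved, which the earlier compounds, with no step among them, could not show. No measurement on hand accounts for this result. As far as these compounds go, whether an amine, a carboxylic acid or a longer chain at this place would also leave the read-out unmoved stays open. So does whether this exchange would read the same way on another core.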